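Carboxy in Place of Hydroxy: A Flat Step Expected

A few compounds are considered here, and "the series" means these few. Any claim that something is new, unique, unknown or untested is made for them only; others in the source may bear on it.

Compound 1 `Cc1c(C(=O)Nc2c(F)cc(-c3cccc(F)c3)cc2F)nc2ccc(OC(F)(F)F)cc2c1O` gives -0.13% in a functional assay on A-375 cells (Homo sapiens) for antiproliferative activity, read by MTT assay, with a stated time of 24 h, tested at 0.05 ug/mL; a higher number here means a stronger effect of the compound at the concentration tested, a lower number a weaker effect.
Compound 2 `Cc1c(C(=O)Nc2c(F)cc(-c3cccc(F)c3)cc2F)nc2ccc(C(F)(F)F)cc2c1O` gives 3.47% in this assay.

Compound 2 holds the nominally upper number of the two, but with compound 1 beside it at a number 3.6 percentage points higher from compound 1 to compound 2 (within the scatter) the two cannot be told apart. Compound 3 `Cc1c(C(=O)Nc2c(F)cc(-c3cccc(F)c3)cc2F)nc2ccc(C(F)(F)F)cc2c1C(=O)O` differs from compound 2 by carboxy in place of hydroxy on an aromatic carbon. Among the compounds with values here, no measured step touches this position; the only step known, a number 3.6 percentage points higher from compound 1 to compound 2 (within the scatter), concerns another site and did not exceed the scatter. Compound 3 is therefore expected to give 3%, between -7% and 13%, a step of a number 0.5 percentage points lower from compound 2 to compound 3 (within the scatter) that is estimated to stay within the scatter.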

Compound 3, a percentage reported as inhibition, at one concentration (the size of the read-out at that concentration, not a potency): 1.04%
The estimate for compound 3 lay 2 percentage points above the measured number, and the stated range covers the measured number.
By their numbers in this assay, from the lowest: compounds 1, 3 and 2 (each within the scatter of the next).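

Carboxy in place of hydroxy gives a number 2.4 percentage points lower from compound 2 to compound 3 (within the scatter) in this assay at this position, the first change measured on the aromatic carbon opposite the ring nitrogen. The site therefore accepts a swap from 1 heavy atom to 3 heavy atoms without a change that can be told from the scatter at the concentration tested. Nothing measured here offers an explanation for this result. The compounds shown leave open whether an amine or a methoxy group on this carbon would move the read-out beyond the scatter.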